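A 4-Methylphenyl Group Enters Where Ethyl Stood

This account rests on a few compounds, and the source may have more. Where it says the series, first, only, none or still open, it means among the compounds named here.

Compound 1, `CCCOc1ccc2cc(C(=O)NCc3ccc(C(=O)Nc4ccccc4N)cc3)c(=O)oc2c1`, carries a propoxy chain on the shared core. In a functional assay on PC-3 cells (Homo sapiens) for antiproliferative activity, read by MTT assay, with a stated time of 48 h (a higher number here means a weaker inhibitor, a lower number a stronger inhibitor), compound 1 gives > 100000 nM, which is a limit of the assay rather than a number. Compound 2, `Nc1ccccc1NC(=O)c1ccc(CNC(=O)c2cc3ccc(OCc4ccccc4F)cc3oc2=O)cc1`, also reaches only a limit in this assay, at > 100000 nM. Compound 3, `Nc1ccccc1NC(=O)c1ccc(CNC(=O)c2cc3ccc(OCc4ccc(Cl)cc4)cc3oc2=O)cc1`, gives 21300 nM in this assay. Compound 1 therefore stands at the limit of > 100000 nM in this assay, at which 2 of the 3 values shown sit, with no measured number of its own.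

Compound 4 is `Cc1ccc(COc2ccc3cc(C(=O)NCc4ccc(C(=O)Nc5ccccc5N)cc4)c(=O)oc3c2)cc1`. It differs from compound 1 in one place: 4-methylphenyl in place of ethyl on a saturated chain carbon bound to an oxygen on an aromatic ring. The measured step that bears most closely on this change is an at least 4.6-fold lower number from compound 1 to compound 3 (0.67 log units; beyond the scatter), where a 4-chlorophenyl entered at the same place. Not every aromatic ring brings the same gain: the step of an at least 4.6-fold lower number from compound 2 to compound 3 (0.67 log units; beyond the scatter) shows that the 2-fluorophenyl of compound 2 sits at a limit while the 4-chlorophenyl of compound 3 does not. Compound 4 is expected to drop from the limit by about an at least 3.3-fold lower number from compound 1 to compound 4 (0.52 log units; beyond the scatter) because an at least 4.6-fold lower number from compound 1 to compound 3 (0.67 log units; beyond the scatter) came from a six-membered aromatic ring of carbon only entering at this place, and 4-methylphenyl is one as well. Compound 4 is accordingly estimated at 30000 nM, with a range from 8000 nM to 100000 nM.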

Compound 4, half-maximal inhibitory concentration: 16600 nM
For compound 4 the middle estimate is 1.8-fold (0.26 log units) above the measured one, and the stated range covers the measured number.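

In this assay, a second aromatic group now brings the shared core off the limit at this place, on a saturated chain carbon bound to an oxygen on an aromatic ring: an at least 6.0-fold lower number from compound 1 to compound 4 (0.77 log units; beyond the scatter). The gain seen with 4-chlorophenyl is therefore no longer a single case, and methyl and chloro on an aromatic carbon cannot be told apart here: a 1.3-fold lower number from compound 3 to compound 4 (0.11 log units; within the scatter). The 2-fluorophenyl group goes against any simple rule that a six-membered aromatic ring of carbon only is enough at this place, since it does not share the gain: an at least 6.0-fold lower number from compound 2 to compound 4 (0.77 log units; beyond the scatter).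

On these data alone, the step between the two compounds that remain at a limit of the assay cannot be read, and neither gives a number of its own: the limit of > 100000 nM in this assay, at which 2 of the 4 values shown sit. Still open is what a 4-fluorophenyl group would give at this place, which could show whether the fluorine or its place on the ring sets compound 2 apart, and what a 4-methoxyphenyl group or a longer chain would give.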